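The source may hold more compounds than are shown below. What is called first, only, known or untested is meant among the compounds shown, and "the series" means these compounds.

Measured in a functional assay on MCF7 cells (Homo sapiens) for antiproliferative activity, read by MTT assay, with a stated time of 48 h; a lower number here means a stronger inhibitor, a higher number a weaker inhibitor:
- compound 1 `CC(=O)OC/C1=C/C[C@](C)(CCC=C(C)C)/C=C/[C@@H](OC(=O)C=C(C)C)[C@](C)(O)/C=C/C1=O`: 4510 nM
- compound 2 `CO[C@]1(C)/C=C/C(=O)/C(CO)=C\C[C@](C)(CCC=C(C)C)/C=C/[C@H]1OC(=O)C=C(C)C`: 14300 nM

Compound 1 has the lower of the two numbers, and its gap to compound 2 lies beyond the scatter. Compound 3 `CC(C)=CCC[C@]1(C)/C=C/[C@@H](OC(=O)C=C(C)C)[C@](C)(O)/C=C/C(=O)/C(CN(C(C)C)C(C)C)=C\C1` departs from compound 1 by diisopropylamino in place of acetoxy on a saturated chain carbon bound to a double-bonded ring carbon. Going by the values given here, no measured pair shows this change, so the expectation is tentative. In this assay, no step beyond the scatter is expected. The estimated step is a 1.3-fold lower number from compound 1 to compound 3 (0.11 log units; within the scatter). For compound 3, the estimated value is 3500 nM, with an expected range of 1100 nM to 12000 nM.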

Compound 3, half-maximal inhibitory concentration: 780 nM
For compound 3 the middle estimate is 4.5-fold (0.65 log units) above the measured one; the measured number lies below the stated range.
By their numbers in this assay, from the lowest: compound 3; then compound 1; then compound 2.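

In this assay, diisopropylamino in place of acetoxy on a saturated chain carbon bound to a double-bonded ring carbon gives a 5.8-fold lower number from compound 1 to compound 3 (0.76 log units; beyond the scatter). This position therefore accepts an amine in place of an ester with a gain beyond the scatter, although this rests on one pair. Nothing measured here accounts for that gain.

The compounds shown leave open whether the gain belongs to diisopropylamino alone or would also appear with a smaller amine such as dimethylamino or a cyclic one such as morpholine. They also leave open whether a carboxylic acid would be accepted at this position.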